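Trading one side chain for another on a free acid

The source may report more compounds than this note shows. Statements on the series, on what has been measured and on what is new or still open speak of the compounds shown alone.

The shared core of compound 2 `CC[C@H](C)[C@H](NC(=O)CN(c1nc(Cl)nc2[nH]cnc12)C1CC1)C(=O)O` carries a free acid. In a functional assay on the whole organism (Tail, strain ICR) with Mus musculus as the target, in the tail flick test, with a stated time of 90 min, at a dose of 25 umol/kg by the oral route (a lower number here means a weaker effect, a higher number a stronger effect of the compound at the dose given), compound 2 gives 27.4%, the lowest of the three numbers measured. Compound 3 `CC[C@H](C)[C@H](NC(=O)CN(c1nc(Cl)nc2[nH]cnc12)C1CC1)C(=O)OCc1ccccc1` gives 36.3%, and compound 1 `CC(C)[C@H](NC(=O)CN(c1nc(Cl)nc2[nH]cnc12)C1CC1)C(=O)OCc1ccccc1` gives 51.3%. Two steps are known: a number 8.9 percentage points higher from compound 2 to compound 3 (within the scatter), and a number 15 percentage points lower from compound 1 to compound 3 (beyond the scatter). Compound 4 `CSCC[C@H](NC(=O)CN(c1nc(Cl)nc2[nH]cnc12)C1CC1)C(=O)O` differs from compound 2 by 2-(methylsulfanyl)ethyl in place of sec-butyl on a saturated chain carbon bound to an amide-type nitrogen and a carbonyl carbon. Going by the values given here, only the step from compound 1 to compound 3 touches the side chain, and it was modest, so a similarly modest shift is expected, with the direction uncertain. Compound 4 is therefore estimated at 30%, between 14% and 46%, an expected step of a number 2.6 percentage points higher from compound 2 to compound 4 (within the scatter).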

Compound 4, a percentage reported as activity, at one dose (the size of the read-out at that dose, not a potency): 14%
Compound 4: the middle estimate sits 16 percentage points above what was measured, within the range that was stated.
By their numbers in this assay, from the lowest: compound 4; then compounds 2 and 3 (each within the scatter of the next); then compound 1.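

On the free acid, this side-chain position responds to the change: in this assay, 2-(methylsulfanyl)ethyl in place of sec-butyl gives a number 13.4 percentage points lower from compound 2 to compound 4 (beyond the scatter) and this lies beyond the scatter. The earlier side-chain step was read only on a benzyl ester, so this is the first such step shown on the acid. Nothing available explains the drop.

The compounds shown leave open whether the same change on the benzyl ester would move the number in the same direction. They also leave open how a longer chain or an amine would behave on this carbon.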